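The source may report more compounds than this note shows. Statements on the series, on what has been measured and on what is new or still open speak of the compounds shown alone.

Compound 1 `COc1ccc(CNC(=O)N2C(=O)c3ccccc3S2(=O)=O)cc1`: 0.187 h
Compound 2 `O=C(NCc1cccc2ccccc12)N1C(=O)c2ccccc2S1(=O)=O`: 0.395 h
Compound 3 `O=C(c1ccccc1)N1Cc2ccccc2S1(=O)=O`: > 166 h

In a physicochemical assay for pharmacokinetics (on this read-out lower numbers stand for a shorter-lived compound and higher numbers for a longer-lived compound), compound 1 gives 0.187 h, the lowest of the two numbers obtained. Compound 2 gives 0.395 h in this assay, a value that lies beyond the scatter above that of compound 1. For compound 3 the assay returns only a limit, > 166 h, as noted in the limit of > 166 h in this assay, at which 1 of the 3 values shown sits.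

Compound 4 `COc1cccc(CNC(=O)N2C(=O)c3ccccc3S2(=O)=O)c1` is not yet measured. It differs from compound 1 in one place: 3-methoxyphenyl in place of 4-methoxyphenyl on a saturated chain carbon bound to an amide-type nitrogen. The two have the same atoms, joined differently, so the step of a 1.1-fold higher number from compound 1 to compound 4 (0.03 log units; within the scatter) is expected to stay within the scatter, with no clear direction. Compound 4 is thus estimated to give 0.2 h in this assay, between 0.09 h and 0.45 h.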

Compound 4, half-life: 0.523 h
The estimate for compound 4 lay 2.6-fold (0.42 log units) below the measured number; the measured number lies above the stated range.
By their numbers in this assay, from the lowest: compound 1; then compounds 2 and 4 (each within the scatter of the next). At a limit, above all of these: compound 3.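

Replacing 4-methoxyphenyl with 3-methoxyphenyl on a saturated chain carbon bound to an amide-type nitrogen is not a silent change in this assay: it gives a 2.8-fold higher number from compound 1 to compound 4 (0.45 log units; beyond the scatter). The earlier compounds shown here could not show this, as none of them differed from another in one place, and here the same atoms, joined differently, separate beyond the scatter. Nothing measured here accounts for this step. On these data alone, it remains open how an amine or a carboxylic acid in place of the methoxy group would behave at this position.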